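Methyl for fluoro on the aryl group of compound 3

A few compounds are considered here, and "the series" means these few. Any claim that something is new, unique, unknown or untested is made for them only; others in the source may bear on it.

Compound 1 `Cc1ccc(-c2ccnc(C(=O)Nc3ccc(Oc4ccnc5[nH]ccc45)cc3)n2)cc1`: 2380 nM
Compound 2 `O=C(Nc1ccc(Oc2ccnc3[nH]ccc23)cc1)c1cc(-c2ccc(F)cc2)ncn1`: 13000 nM
Compound 3 `O=C(Nc1ccc(Oc2ccnc3[nH]ccc23)c(F)c1)c1cc(-c2ccc(F)cc2)ncn1`: 14200 nM

In a functional assay on A549 cells (Homo sapiens) for cytotoxicity, read by MTT assay, with a stated time of 72 h (a higher number here means a weaker inhibitor, a lower number a stronger inhibitor), compound 3 gives the highest of the three numbers; compound 2 lies within the scatter of it, as the step of a 1.1-fold higher number from compound 2 to compound 3 (0.04 log units; within the scatter) shows, while compound 1 sits well below it. Compound 4 `Cc1ccc(-c2cc(C(=O)Nc3ccc(Oc4ccnc5[nH]ccc45)c(F)c3)ncn2)cc1` differs from compound 3 by methyl in place of fluoro on an aromatic carbon. Within the data shown here, no measured step covers this change alone: compound 1 also carries a methyl, but it differs from compound 2 in more than one place, so their values show only that the methyl compound gives the lower number. Compound 4 is therefore expected to give a somewhat lower number, a step of a 2.4-fold lower number from compound 3 to compound 4 (0.37 log units; beyond the scatter), and is estimated at 6000 nM with a range from 2000 nM to 18000 nM.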

Compound 4, half-maximal inhibitory concentration: 8600 nM
Compound 4: the middle estimate sits 1.4-fold (0.16 log units) below what was measured; the measured number falls inside the stated range.
By their numbers in this assay, from the lowest: compound 1; then compounds 4, 2 and 3 (each within the scatter of the next).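

Among these compounds, the step of a 1.7-fold lower number from compound 3 to compound 4 (0.22 log units; within the scatter) gives the first direct reading of this change in this assay, and it lies within the scatter. On an aromatic carbon para to a large group, 4-fluorophenyl and 4-methylphenyl therefore cannot be told apart in this assay, at least with the rest of compound 3 held fixed. No measurement available here bears on this result.

Going by these compounds, whether an amine or a carboxylic acid at this place would move the number beyond the scatter remains open. So does whether the methyl would behave the same way on the core of compound 2.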